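Dichloropurine variants of the chloromethylbenzyl series

This account rests on a few compounds, and the source may have more. Where it says the series, first, only, none or still open, it means among the compounds named here.

Three compounds of this series have been run through a functional assay on MDA-MB-435 cells (Homo sapiens) for cytotoxicity, read by sulforhodamine B assay, with a stated time of 48 h; a higher number here means a weaker inhibitor of growth, a lower number a stronger inhibitor of growth. Compound 1 `ClCc1ccc(Cn2cnc3c(Cl)ncnc32)cc1` gives 4360 nM in this assay, and compound 2 `ClCc1ccccc1Cn1cnc2ncnc(Cl)c21` gives 3800 nM. The two have the same atoms joined differently; the difference between the two cores is not broken down here, and the two values lie within the usual scatter of each other. Compound 3 `ClCc1ccc(Cn2cnc3c(Cl)nc(Cl)nc32)cc1` gives 25100 nM in this assay. Its relation to compound 1 is counted: chloro in place of hydrogen on an aromatic carbon. That change produced a 5.8-fold higher number from compound 1 to compound 3 (0.76 log units; beyond the scatter), a modest but clear loss of growth inhibition.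

Compound 4 `ClCc1ccccc1Cn1cnc2nc(Cl)nc(Cl)c21` has not yet been measured in this assay. It differs from compound 2 by chloro in place of hydrogen on an aromatic carbon. The place of the entering chloro group is described in the same words as for the change from compound 1 to compound 3, so it is the same change, applied to the core of compound 2 instead of the core of compound 1. The change is seen only once among the measured compounds, so its transfer to the other core is an assumption rather than an established pattern.

On that single precedent, the expected step from compound 2 to compound 4 is a 5.3-fold higher number from compound 2 to compound 4 (0.72 log units; beyond the scatter), resting on the step of a 5.8-fold higher number from compound 1 to compound 3 (0.76 log units; beyond the scatter). Compound 4 is accordingly estimated at 20000 nM in this assay, with a range of 8000 nM to 50000 nM allowing for the scatter of this kind of measurement and for the untested transfer between cores.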

Compound 4, concentration for total growth inhibition: 30900 nM
For compound 4 the middle estimate is 1.5-fold (0.19 log units) below the measured one; measured number inside the range.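

Working note on the second core: chloro in place of hydrogen on an aromatic carbon, between two ring nitrogen atoms, gives an 8.1-fold higher number from compound 2 to compound 4 (0.91 log units; beyond the scatter) in this assay, so the loss of growth inhibition seen on the first core appears again on the second. The two steps point the same way and do not differ in size beyond what repeated measurement allows: the same change on two cores in this assay, a 5.8-fold higher number (0.76 log units; beyond the scatter) from compound 1 to compound 3 and an 8.1-fold higher number (0.91 log units; beyond the scatter) from compound 2 to compound 4, 1.4-fold (0.15 log units) apart, within the scatter of two such steps

Among these compounds, this supports carrying the change between these two cores in this assay, but it rests on only two matched pairs, so it sets no rule for other cores or other cell lines and gives no explanation for the rise in the number.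

Still open, from the compounds shown here alone, is whether a different group on the same aromatic carbon, such as an amine, a methoxy group or a methyl group, would give a step like that of chloro or leave the number close to that of the parent with hydrogen. Also open, going by these compounds, is whether the step would keep its direction and size on cores carrying something other than the chloromethyl group, such as a hydroxymethyl group or a longer chain.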